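A few compounds are considered here, and "the series" means these few. Any claim that something is new, unique, unknown or untested is made for them only; others in the source may bear on it.

Measured so far in an ADME assay on HEK293 cells (Homo sapiens) for cytotoxicity, read by MTT assay, with a stated time of 3 days; on this read-out lower numbers stand for stronger inhibition and higher numbers for weaker inhibition:
Compound 1 `COc1ccccc1-c1cccc(O)c1` gives 50 ug/mL.
Compound 2 `Nc1ccccc1-c1cccc(O)c1` gives 10.5 ug/mL.
Compound 3 `COc1ccc(-c2cccc(O)c2)cc1` gives 14.6 ug/mL.

Compound 2 differs from compound 1 by one change, (amino in place of methoxy on an aromatic carbon), and this gave a 4.8-fold lower number from compound 1 to compound 2 (0.68 log units; beyond the scatter). The difference between the core of compound 1 and the core of compound 3 is not broken down here. Compound 4 `Nc1ccc(-c2cccc(O)c2)cc1` is still to be tested; it differs from compound 3 by amino in place of methoxy on an aromatic carbon. This is the same kind of change as before, but not the same: in compound 2 the amino group sits ortho to a group of 7 heavy atoms, in compound 4 it sits para to it. Resting on the step seen in a 4.8-fold lower number from compound 1 to compound 2 (0.68 log units; beyond the scatter), the change from compound 3 is expected to give a 2.9-fold lower number from compound 3 to compound 4 (0.47 log units; beyond the scatter), leading to an estimate for compound 4 of 5 ug/mL.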

Compound 4, half-maximal inhibitory concentration: 55 ug/mL
For compound 4 the middle estimate is 11-fold (1.04 log units) below the measured one; the whole stated range lies below it.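

In this assay, putting amino in place of methoxy did not carry over from one core to the other: here the number went the opposite way, with a 3.8-fold higher number from compound 3 to compound 4 (0.58 log units; beyond the scatter). Set side by side, the two steps clearly disagree: the same change on two cores in this assay, a 4.8-fold lower number (0.68 log units; beyond the scatter) from compound 1 to compound 2 and a 3.8-fold higher number (0.58 log units; beyond the scatter) from compound 3 to compound 4, 18-fold (1.25 log units) apart, beyond the scatter of two such steps. So the result of this change in this series cannot be assumed from one core to the next, but two pairs do not show whether the core itself or the place of the group decides the outcome, and they give no general rule.

The compounds shown leave open how other groups would behave in the same place. A carboxylic acid or an ethoxy group on each core would show whether the reversal is peculiar to amino.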